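Selenium for sulfur on the amidine carbon of compound 3

The source may hold more compounds than are shown below. What is called first, only, known or untested is meant among the compounds shown, and "the series" means these compounds.

Compound 1, `O=C(/N=C(/NC(=O)c1ccno1)[Se]Cc1ccccc1)c1ccno1`, in a functional assay on PC-3 cells (Homo sapiens) for cytotoxicity, read by MTT assay, with a stated time of 72 h (on this read-out lower numbers stand for stronger inhibition of growth and higher numbers for weaker inhibition of growth), gives > 100000 nM, a limit of the assay.
Compound 2, `O=C(/N=C(/NC(=O)c1cc(-c2ccccc2)nc2ccccc12)[Se]Cc1ccccc1)c1cc(-c2ccccc2)nc2ccccc12`, in this assay gives 97100 nM.
Compound 3, `CS/C(=N\C(=O)c1cc(-c2ccccc2)nc2ccccc12)NC(=O)c1cc(-c2ccccc2)nc2ccccc12`, in this assay gives > 100000 nM, a limit of the assay.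

Compound 3 therefore stands only at a limit of the assay, and that limit is shared by compound 1, as noted in the limit of > 100000 nM in this assay, at which 2 of the 3 values shown sit. Among the measured compounds shown here, compound 2 is the one measured member with a number, and it sits close to that same limit.

Compound 4, `C[Se]/C(=N\C(=O)c1cc(-c2ccccc2)nc2ccccc12)NC(=O)c1cc(-c2ccccc2)nc2ccccc12`, differs from compound 3 by a group of 2 heavy atoms (1 carbon, 1 selenium; no ring) in place of a group of 2 heavy atoms (1 carbon, 1 sulfur; no ring), on a carbon with a double bond to nitrogen. For the measured compounds named here, the one measured step that touches this position is an at least 1.0-fold higher number from compound 2 to compound 3 (0.01 log units; that floor lies within the scatter), which exchanged a benzyl-bearing selenium group for methylsulfanyl and left the read-out where it was, within the scatter. The change from compound 3 to compound 4 is smaller, keeping the single-carbon chain and only exchanging sulfur for selenium, so no step beyond the scatter in this assay is expected, with a fair chance that compound 4 again reports only a limit.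

Compound 4 is therefore estimated at 100000 nM, between 50000 nM and 200000 nM, a step of a number no higher from compound 3 to compound 4 (the limit leaves the size open) that is expected to lie within the scatter.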

Compound 4, concentration for total growth inhibition: 40200 nM
The estimate for compound 4 lay 2.5-fold (0.40 log units) above the measured number; the measured number lies below the stated range.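

In this assay, the exchange of methylsulfanyl for its selenium counterpart on the carbon with a double bond to nitrogen gives an at least 2.4-fold lower number from compound 3 to compound 4 (0.39 log units; beyond the scatter), so this position responds to the identity of the atom itself, even with the single-carbon chain kept. On these data alone, the true size of this step stays open because compound 3 sits at a limit and yields only a floor: the limit of > 100000 nM in this assay, at which 2 of the 4 values shown sit. Within the selenium pair, the step is a 2.4-fold lower number from compound 2 to compound 4 (0.38 log units; beyond the scatter), which shows that hydrogen in place of phenyl on the saturated chain carbon bound to the selenium atom also moves the read-out beyond the scatter, something the earlier step, with sulfur and the smaller group entering together, did not reveal.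

The compounds shown leave open whether methoxy on the same carbon would follow the sulfur or the selenium compound, and whether an ethyl chain on the selenium would stand with compound 4 or with compound 2. They also leave open why the selenium compound gives the lower number, and whether an amine or a carboxylic acid on the benzyl ring of compound 2 would change its reading.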